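Replacing the aryl hydrazide with an acyl hydrazide

The source may hold more compounds than are shown below. What is called first, only, known or untested is meant among the compounds shown, and "the series" means these compounds.

Among the measured compounds shown here, the two measured members of this set share a core carrying a sulfonamide-linked dihydroxypyrimidine and a benzohydrazide arm. Compound 1 `O=C(NNc1ccccc1F)c1ccc(NS(=O)(=O)c2cnc(O)nc2O)cc1` carries a 2-fluorophenyl on the terminal hydrazide nitrogen. In a functional assay on OVCAR-3 cells (Homo sapiens) for antiproliferative activity, read by MTT assay, with a stated time of 24 h (a higher number here means a weaker inhibitor, a lower number a stronger inhibitor), compound 1 returns only a limit, > 20000 nM. Compound 2 `Cc1cccc(NNC(=O)c2cccc(NS(=O)(=O)c3cnc(O)nc3O)c2)c1` bears a 3-methylphenyl at the same position, with the hydrazide moved to the other ring position. In this assay compound 2 likewise gives only a limit, > 20000 nM, so where it stands within the measurable range is not known. Both values rest at the same point, as noted in the limit of > 20000 nM in this assay, at which 2 of the 2 values shown sit.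

Compound 3 `O=C(NNC(=O)c1ccccc1Cl)c1cccc(NS(=O)(=O)c2cnc(O)nc2O)c1` is the unmeasured relative of compound 2. The change is (2-chlorophenyl)carbonyl in place of 3-methylphenyl on an amine nitrogen, which turns the aryl hydrazine into a diacyl hydrazide. For the measured compounds named here, no measured step between any pair is available, so the size of the step can only be guessed. With both neighbours at the limit, the expected step from compound 2 to compound 3 is a step that the limit leaves unreadable from compound 2 to compound 3, with no clear direction beyond the scatter. Compound 3 is therefore estimated at 25000 nM, in the range 7000 nM to 90000 nM.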

Compound 3, half-maximal inhibitory concentration: 7300 nM
Estimate against measurement, compound 3: 3.4-fold (0.53 log units) above; measured number inside the range.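

Among the compounds shown here, compound 3 is the first member of this set to give a number rather than a limit in this assay, at 7300 nM, which shows that this amine nitrogen is a position where a change can bring the read-out into the measurable range. Placing (2-chlorophenyl)carbonyl there in place of 3-methylphenyl gives an at least 2.7-fold lower number from compound 2 to compound 3 (0.43 log units; beyond the scatter), so the direction of the change is now known and lies beyond the scatter. The full size of the step remains unknown, since compound 2 is held at a limit: the limit of > 20000 nM in this assay, at which 2 of the 3 values shown sit.

The compounds shown do not separate the contribution of the carbonyl from that of the chlorine, as the entering group brings both at once and the 2-chlorophenyl ring is not seen without either. From the compounds shown here alone, it also remains open whether a plain benzoyl, a small acetyl or a group ending in a carboxylic acid on the same amine nitrogen would give a measurable value, and whether the number can be brought lower still.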